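The source may report more compounds than this note shows. Statements on the series, on what has been measured and on what is new or still open speak of the compounds shown alone.

Measured so far in a functional assay on SK-OV-3 cells (Homo sapiens) for cytotoxicity; on this read-out higher numbers stand for weaker inhibition and lower numbers for stronger inhibition:
compound 1 `C=C/C=C\[C@H](C)[C@H](OC(N)=O)[C@@H](C)[C@H](O)[C@@H](C)C/C(C)=C\[C@H](C)[C@@H](O)[C@@H](C)/C=C\CCc1cccc(O)c1` gives 40 nM;
compound 2 `C=C/C=C\[C@H](C)[C@H](OC(N)=O)[C@@H](C)[C@H](O)[C@@H](C)C/C(C)=C\[C@H](C)[C@@H](O)[C@@H](C)/C=C\CCc1ccsc1` gives 440 nM;
compound 3 `C=C/C=C\[C@H](C)[C@H](OC(N)=O)[C@@H](C)[C@H](O)[C@@H](C)C/C(C)=C\[C@H](C)[C@@H](O)[C@@H](C)/C=C\CCc1cccc(Cl)c1` gives 380 nM.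

Compound 3 stands second highest of the three numbers; against compound 2 the difference is a 1.2-fold lower number from compound 2 to compound 3 (0.06 log units; within the scatter), while the larger gap is a 9.5-fold higher number from compound 1 to compound 3 (0.98 log units; beyond the scatter). Compound 4 `C=C/C=C\[C@H](C)[C@H](OC(N)=O)[C@@H](C)[C@H](O)[C@@H](C)C/C(C)=C\[C@H](C)[C@@H](O)[C@@H](C)/C=C\CCc1cccc(OC)c1` is not yet measured. The change from compound 3 to compound 4 is methoxy in place of chloro on an aromatic carbon. For the measured compounds named here, the step that bears on it is the one from compound 1 to compound 3, a hydroxy-to-chloro swap on the same aromatic carbon, which gave a 9.5-fold higher number from compound 1 to compound 3 (0.98 log units; beyond the scatter). A methoxy keeps the hydrogen-bond acceptor of the hydroxy but not its donor, so in this assay compound 4 is expected to recover part of that loss, a step of a 2.5-fold lower number from compound 3 to compound 4 (0.40 log units; beyond the scatter). The estimate for compound 4 is 150 nM, range 50 nM to 500 nM.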

Compound 4, half-maximal inhibitory concentration: 370 nM
Estimate against measurement, compound 4: 2.5-fold (0.39 log units) below; the range from low to high includes it.
By their numbers in this assay, from the lowest: compound 1; then compounds 4, 3 and 2 (each within the scatter of the next).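

In this assay, methylating the oxygen is enough to lose the standing of compound 1: a 9.3-fold higher number from compound 1 to compound 4 (0.97 log units; beyond the scatter), a step of the same order as the swap to chloro. Methoxy and chloro do not separate at this aromatic carbon, with a 1.0-fold lower number from compound 3 to compound 4 (0.01 log units; within the scatter), and the thiophen-3-yl analogue joins them, with a 1.2-fold lower number from compound 2 to compound 4 (0.08 log units; within the scatter), so among these four only the hydroxy compound stands apart. No data here explain this. From the compounds shown here alone, whether an amine or a hydroxymethyl on this aromatic carbon would match compound 1 remains open.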